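Chloro on the Outer Ring of a Chalcone-like Scaffold

This account rests on a few compounds, and the source may have more. Where it says the series, first, only, none or still open, it means among the compounds named here.

Compound 1 `O=C(/C=C/c1ccccc1)c1ccc[nH]1` is the parent of this small set. In a functional assay on PC-3 cells (Homo sapiens) for inhibition, read by MTT assay, with a stated time of 48 h (a lower number here means a stronger inhibitor, a higher number a weaker inhibitor), compound 1 gives > 100000 nM, which is a limit of the measurement rather than a number, so its position is known only through (the limit of > 100000 nM in this assay, at which 1 of the 3 values shown sits). Two measured changes grow out of it. Compound 2 `COc1cccc(/C=C/C(=O)c2ccc[nH]2)c1` carries a methoxy group and gives 24000 nM, a move of an at least 4.1-fold lower number from compound 1 to compound 2 (0.61 log units; beyond the scatter). Compound 3 `O=C(/C=C/c1ccccc1Br)c1ccc[nH]1` carries a bromo group and gives 44000 nM, a move of an at least 2.2-fold lower number from compound 1 to compound 3 (0.35 log units; beyond the scatter). Compound 4 `O=C(/C=C/c1ccc(Cl)cc1)c1ccc[nH]1` has not been measured; it differs from compound 1 by chloro in place of hydrogen on an aromatic carbon. Both measured steps replace a hydrogen on the six-membered aromatic ring of carbon only with a single group and both lower the number beyond the scatter, so a similar, modest lowering is expected here. The closest parallel is the bromo step, another halogen, and the expected step is an at least 2.5-fold lower number from compound 1 to compound 4 (0.39 log units; beyond the scatter). Compound 4 is therefore estimated at 40000 nM, with a plausible range from 15000 nM to 150000 nM.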

Compound 4, half-maximal inhibitory concentration: 18000 nM
Compound 4: the middle estimate sits 2.2-fold (0.35 log units) above what was measured; the measured number falls inside the stated range.
By their numbers in this assay, from the lowest: compounds 4, 2 and 3 (each within the scatter of the next, the first and the last beyond it). At a limit, above all of these: compound 1.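

Chloro on an aromatic carbon para to a group of 9 heavy atoms gives an at least 5.5-fold lower number from compound 1 to compound 4 (0.74 log units; beyond the scatter). This adds a third single group on the six-membered ring of the core of compound 1, and all three groups shown lower the number beyond the scatter, so none goes against this pattern in this small set. Compound 1 is known only as a limit and not as a number, so this step has a smallest possible size but no exact size: the limit of > 100000 nM in this assay, at which 1 of the 4 values shown sits.

Going by these compounds, what an amine or a carboxylic acid would do on this same carbon remains open, as does whether chloro on a different carbon of the ring would give a similar step. The compounds shown also cannot tell why chloro lowers the number here.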